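Compound 3 to compound 4: exchanging the 1,3-benzoxazol-2-yl group

The source may report more compounds than this note shows. Statements on the series, on what has been measured and on what is new or still open speak of the compounds shown alone.

In a functional assay on K562 cells (Homo sapiens) for antiproliferative activity, read by MTT assay, with a stated time of 48 h (a lower number here means a stronger inhibitor, a higher number a weaker inhibitor), compound 1 `N#Cc1nc2c(-c3nc4ccccc4o3)c(N)n(CCCN3CCCCC3)c2nc1C#N` gives only a limit, > 50000 nM. Compound 2 `CN(C)CCCCn1c(N)c(-c2nc3ccccc3o2)c2nc(C#N)c(C#N)nc21` gives 1380 nM and compound 3 `CCN(CC)CCCCn1c(N)c(-c2nc3ccccc3o2)c2nc(C#N)c(C#N)nc21` gives 1980 nM, a pair separated by a 1.4-fold higher number from compound 2 to compound 3 (0.16 log units; within the scatter). Compound 4 `CCN(CC)CCCCn1c(N)c(-c2nc3ccccc3n2C)c2nc(C#N)c(C#N)nc21` keeps the 4-(diethylamino)butyl group of compound 3 but carries 1-methyl-1H-benzimidazol-2-yl in place of 1,3-benzoxazol-2-yl on an aromatic carbon. The measured steps all lie in the amine chain, namely an at least 25-fold lower number from compound 1 to compound 3 (1.40 log units; beyond the scatter) and the small step above, and none touches this aromatic group. They give no direction, so no step beyond the scatter is expected. The step expected is a 1.3-fold higher number from compound 3 to compound 4 (0.10 log units; within the scatter). Compound 4 is estimated at 2500 nM, within a range of 700 nM to 9000 nM.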

Compound 4, half-maximal inhibitory concentration: 1010 nM
Beside the measured number, compound 4's estimate is 2.5-fold (0.39 log units) above it; low and high end bracket the measured number.
By their numbers in this assay, from the lowest: compounds 4, 2 and 3 (each within the scatter of the next). At a limit, above all of these: compound 1.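

The first change shown at this aromatic carbon, 1-methyl-1H-benzimidazol-2-yl in place of 1,3-benzoxazol-2-yl, gives a 2.0-fold lower number from compound 3 to compound 4 (0.29 log units; within the scatter) in this assay. This position therefore accepts this exchange with the 4-(diethylamino)butyl group in place, with no step beyond the scatter. Nothing measured here gives a cause for this step.

The compounds shown leave open whether an unsubstituted 1H-benzimidazol-2-yl group or a plain phenyl ring would fare alike here. They also leave open whether the exchange holds with the dimethylamino chain of compound 2.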